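The source may hold more compounds than are shown below. What is called first, only, known or untested is meant among the compounds shown, and "the series" means these compounds.

Measured so far in an ADME assay on HEK293 cells (Homo sapiens) for cytotoxicity, with a stated time of 72 h; on this read-out lower numbers stand for an effect already at smaller amounts and higher numbers for an effect only at larger amounts of compound:
Compound 1 `C=C[C@@](C)(/C=C/c1ccc(OCc2ccccc2)cc1)CCC=C(C)C`: > 36600 nM (a limit)
Compound 2 `C=C[C@@](C)(/C=C/c1ccc(O)c(/C=C/C=C/c2ccccc2)c1)CCC=C(C)C`: > 36600 nM (a limit)

Compound 1 has no exact number in this assay, only the limit > 36600 nM. Compound 2 likewise gives only a limit, > 36600 nM. Among the compounds with values here, the only reading available so far is the limit of > 36600 nM in this assay, at which 2 of the 2 values shown sit. Within the data shown here, no step between measured compounds can therefore be sized.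

Compound 3 `C=C[C@@](C)(/C=C/c1ccc(Nc2ccc(F)cc2)cc1)CCC=C(C)C` has not yet been measured. It differs from compound 1 by one exchange: (4-fluorophenyl)amino in place of benzyloxy on an aromatic carbon. In words, (4-fluorophenyl)amino stands in place of benzyloxy on an aromatic carbon, para to a large group.

The expectation rests on compound 1, whose limit of > 36600 nM gives a starting point but no exact number. No direction can be drawn from the data, and no change beyond the usual scatter is expected in this assay. The estimated step is a step that the limit leaves unreadable from compound 1 to compound 3. For compound 3 the expected value is 37000 nM, with an estimated range of 15000 nM to 70000 nM. The assay may well again report only a limit.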

Compound 3, half-maximal effective concentration: > 36600 nM
Compound 3 gave a limit, no number; the forecaster's own chance of this, stated with the estimate: 70%; the middle value is on the limit's open side.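

In this assay, within the data shown here, compound 1 and compound 3 both give only a limit, and no step between them can be read. The compounds shown leave open whether (4-fluorophenyl)amino in place of benzyloxy on an aromatic carbon shifts this read-out at all, with every reading shown sitting at one limit: the limit of > 36600 nM in this assay, at which 3 of the 3 values shown sit.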